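The compounds below may be only part of what the source reports. "The series", "measured", "known", "first", "only" and "open" are said of these compounds alone.

Measured so far in a functional assay on HepG2 cells (Homo sapiens) for inhibition, read by MTT assay, with a stated time of 48 h, tested at 2 uM; a lower number here means less inhibition, a higher number more inhibition at the concentration tested (going by the name of the read-out): compound 1 `Cc1nc(-c2ccccc2)sc1CN1C(=O)N(C)c2ccc(-c3c(C)noc3C)cc2C1c1ccccc1` gives 29.2%; compound 2 `Cc1noc(C)c1-c1ccc2c(c1)C(c1ccccc1)N(Cc1nc(-c3ccccc3)cs1)C(=O)N2C` gives 44.5%; compound 3 `Cc1nc(-c2ccc(F)cc2)sc1CN1C(=O)N(C)c2ccc(-c3c(C)noc3C)cc2C1c1ccccc1` gives 26.4%.

The two cores of the series differ by 4-phenyl-1,3-thiazol-2-yl in place of 4-methyl-2-phenyl-1,3-thiazol-5-yl on a saturated chain carbon bound to an amide-type nitrogen in a ring. That change gives a number 15.3 percentage points higher from compound 1 to compound 2 (beyond the scatter), and compound 2 stands highest of the three measured numbers, with the other two beyond the scatter below it. On the core of compound 1, the change fluoro in place of hydrogen on an aromatic carbon gives a number 2.8 percentage points lower from compound 1 to compound 3 (within the scatter), so the two values of compound 1 and compound 3 are not told apart by this assay.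

Compound 4 `Cc1noc(C)c1-c1ccc2c(c1)C(c1ccccc1)N(Cc1nc(-c3ccc(F)cc3)cs1)C(=O)N2C` is the unmeasured partner of compound 2 and carries the same change, (fluoro in place of hydrogen on an aromatic carbon); the place is worded the same in both cases. Going by the values given here, only one earlier instance of this change is at hand, so the expectation rests on a single pair. The step from compound 2 is expected to be a number 2.5 percentage points lower from compound 2 to compound 4 (within the scatter), small, because compound 3 showed a number 2.8 percentage points lower from compound 1 to compound 3 (within the scatter) on the other core. Compound 4 is therefore estimated at 42% in this assay, expected to fall between 30% and 54%.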

Compound 4, a percentage reported as inhibition, at one concentration (the size of the read-out at that concentration, not a potency): 41.1%
The estimate for compound 4 lay 0.9 percentage points above the measured number; the range from low to high includes it.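

In this assay, fluoro in place of hydrogen on an aromatic carbon para to a large group gives a number 3.4 percentage points lower from compound 2 to compound 4 (within the scatter), and the change reads alike on the two cores: the same change on two cores in this assay, a number 2.8 percentage points lower (within the scatter) from compound 1 to compound 3 and a number 3.4 percentage points lower (within the scatter) from compound 2 to compound 4, 0.6 percentage points apart, within the scatter of two such steps. The gap between the cores also remains readable with fluoro present, at a number 11.9 percentage points higher from compound 1 to compound 4 (beyond the scatter). This shows that the change carries over between these two cores without a step that the assay can resolve, but it gives the change no established size or direction, and two pairs at a single concentration say nothing about potency or about other cores.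

Among the compounds shown, only hydrogen and fluoro occupy this place, so it remains open whether chloro, methoxy or an amine there would give a step beyond the scatter. Also open, from the compounds shown here alone, is whether a longer chain in place of the methyl of the 4-methyl-2-phenyl-1,3-thiazol-5-yl group would alter the gap between the cores.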